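The source may report more compounds than this note shows. Statements on the series, on what has been measured and on what is new or still open speak of the compounds shown alone.

Three compounds of the series carry numbers in an assay on isolated protein for inhibition of serine protease 1 (Homo sapiens), read by fluorescence; a lower number here means a stronger inhibitor, a higher number a weaker inhibitor. Compound 3 `CNC(=O)[C@@H]1C[C@H](N2CCc3c(ncnc3OCCc3ccccc3)C2)CN1C(=O)c1ccc(CN)c(OC)c1` gives 5 nM, compound 1 `CNC(=O)[C@@H]1C[C@H](N2CCc3c(cccc3OC)C2)CN1C(=O)c1ccc(CN)c(OC)c1` gives 100 nM, and compound 2 `CNC(=O)[C@@H]1C[C@H](n2cc(C3CC3)nn2)CN1C(=O)c1ccc(CN)c(OC)c1` gives 2100 nM, the highest of the three and beyond the scatter from both others. Compound 4 `COc1cc(C(=O)N2C[C@@H](n3cc(C4CC4)nn3)C[C@H]2C(=O)N[C@@H]2C[C@H]2c2ccccc2)ccc1CN` keeps the core of compound 2 and differs from it in one place: 2-phenylcyclopropyl in place of methyl on an amide-type nitrogen. Among the measured compounds shown here, no measured pair in this assay covers that change, so nothing here fixes its direction. A step of moderate size toward a lower number is nonetheless expected, a 3.0-fold lower number from compound 2 to compound 4 (0.48 log units; beyond the scatter), with wide uncertainty. For compound 4 the estimate in this assay is 700 nM, with a range of 150 nM to 3000 nM.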

Compound 4, half-maximal inhibitory concentration: 110 nM
Compound 4: the middle estimate sits 6.4-fold (0.80 log units) above what was measured, and the stated range ends above it.
By their numbers in this assay, from the lowest: compound 3; then compounds 1 and 4 (each within the scatter of the next); then compound 2.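

In this assay, the first pair differing in one place gives a 19-fold lower number from compound 2 to compound 4 (1.28 log units; beyond the scatter), with the rest of the structure unchanged. The amide-type nitrogen is therefore a position where the number responds strongly, and replacing methyl with 2-phenylcyclopropyl moves it toward stronger inhibition. Nothing available explains this step.

Still open, going by these compounds, is whether the three-membered ring, the aromatic ring or the two defined stereocentres account for the step, which a benzyl or phenyl group on the same nitrogen would help separate. On these data alone, whether the change carries over to the core of compound 1 or compound 3 also remains open.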